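The compounds below may be only part of what the source reports. "The series", "measured", "known", "first", "only" and "open" are said of these compounds alone.

Three compounds have been measured in a functional assay on CHO cells with adenosine receptor A1 (Homo sapiens) as the target, read by cAMP accumulation and immunoassay, with a stated time of 6 min, tested at 1 uM; on this read-out higher numbers stand for a weaker effect at the one concentration tested and lower numbers for a stronger effect:

compound 1 `COc1ccc(N2CCN(Cc3csc(N)c3C(=O)c3ccc(Cl)cc3)CC2)cc1`: -15%
compound 2 `Nc1scc(CN2CCN(c3cccc4ccccc34)CC2)c1C(=O)c1ccc(Cl)cc1`: 2.9%
compound 3 `Nc1scc(CN2CCN(c3ccccc3F)CC2)c1C(=O)c1ccc(Cl)cc1`: -9.2%

All three share the same core and differ only in the group carried by the ring nitrogen. Compound 3 holds the second highest of the three numbers. Its nearest neighbour is compound 1, with a number 5.8 percentage points higher from compound 1 to compound 3 (within the scatter), so these two cannot be told apart; its furthest is compound 2, with a number 12.1 percentage points lower from compound 2 to compound 3 (beyond the scatter).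

The step to compound 4 `Nc1scc(CN2CCN(CCCc3ccc(Cl)cc3)CC2)c1C(=O)c1ccc(Cl)cc1` changes that same position: 3-(4-chlorophenyl)propyl in place of 2-fluorophenyl on an amine nitrogen in a ring. Every measured step swaps one aromatic group for another on this nitrogen, and they were a number 17.9 percentage points higher from compound 1 to compound 2 (beyond the scatter), a number 5.8 percentage points higher from compound 1 to compound 3 (within the scatter) and a number 12.1 percentage points lower from compound 2 to compound 3 (beyond the scatter): at most modest. None of them puts a chain on the nitrogen, so the new change is only loosely covered. Given that the measured swaps moved the read-out modestly at best, no step beyond the scatter is expected for a number 4.2 percentage points higher from compound 3 to compound 4 (within the scatter). Compound 4 is therefore estimated at -5%, with a range from -25% to 15%.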

Compound 4, a percentage reported as activity, at one concentration (the size of the read-out at that concentration, not a potency): -30%
For compound 4 the middle estimate is 25 percentage points above the measured one; measured number outside the range, below it.
By their numbers in this assay, from the lowest: compound 4; then compounds 1 and 3 (each within the scatter of the next); then compound 2.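

Replacing a ring joined directly to the amine nitrogen in the ring with 3-(4-chlorophenyl)propyl, where a chain separates the aromatic ring from that nitrogen, gives a clear shift in this assay against each earlier compound: (a number 20.8 percentage points lower from compound 3 to compound 4 (beyond the scatter)), (a number 15 percentage points lower from compound 1 to compound 4 (beyond the scatter)) and (a number 32.9 percentage points lower from compound 2 to compound 4 (beyond the scatter)). Compound 4 therefore has the lowest number of the four, which on this read-out stands for the strongest effect at the one concentration tested, so this position responds to more than swaps among directly attached aromatic groups. Nothing available here explains the shift.

Two things change at once in this step, the chain and the swap of fluorine for chlorine on a ring that also sits in a different arrangement, so the compounds shown cannot separate their contributions. A 3-phenylpropyl group, without the chlorine, and a shorter 2-(4-chlorophenyl)ethyl group would help to separate them, while a plain propyl chain would show whether the aromatic ring is needed at all.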